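The source may report more compounds than this note shows. Statements on the series, on what has been measured and on what is new or still open speak of the compounds shown alone.

Compound 1, `COc1cc2nc(N3CCCN(C(=O)N4CCOCC4)CC3)nc(N)c2c(-c2ccccn2)c1OC`, gives 34 mL/min/kg in an in vitro ADME assay on microsomes from liver (Homo sapiens) for metabolic stability, tested at 1 uM; a lower number here means slower removal, a higher number faster removal of the compound.
Compound 2, `COc1cc2nc(N3CCCN(C(=O)N4CCOCC4)CC3)cc(N)c2c(-c2ccccc2)c1OC`, gives 82 mL/min/kg in this assay.
Compound 3, `COc1cc2nc(N3CCc4ncccc4C3)nc(N)c2c(-c2ncccn2)c1OC`, gives 12 mL/min/kg in this assay.

Among these three, compound 2 shows the highest clearance of the set, so it is the one removed fastest. Its nearest neighbour is compound 1, whose number is lower by a gap that lies beyond the usual scatter of repeated measurements, and the gap to compound 3 is wider still. None of these three pairs differs in only one place, so nothing can be said about what any single change does here; the numbers only show where each compound sits.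

The next compound, compound 4, `COc1cc2nc(N3CCCN(C(=O)N4CCOCC4)CC3)cc(N)c2c(-c2ccc(F)cc2)c1OC`, is built from compound 2 with one change: fluoro in place of hydrogen on an aromatic carbon. Among the compounds with values here, since no single-change pair has been measured, there is no direct precedent for the size of this step in this assay. A small change of one heavy atom on an outer aromatic ring is expected to move the clearance only modestly, probably a little downward, and most likely not beyond the scatter of the method.

For compound 4 the expected clearance in this assay is 65 mL/min/kg, within a range from 35 mL/min/kg to 120 mL/min/kg. The estimated step of a 1.3-fold lower number from compound 2 to compound 4 (0.10 log units; within the scatter) is therefore expected to be small.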

Compound 4, clearance: 154 mL/min/kg
Compound 4: the middle estimate sits 2.4-fold (0.37 log units) below what was measured; the whole stated range lies below it.
By their numbers in this assay, from the lowest: compound 3; then compound 1; then compounds 2 and 4 (each within the scatter of the next).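

Within the data shown here, compound 2 and compound 4 form the first pair here that differs in only one place, so the effect of a single change can finally be read in this assay. Putting fluoro in place of hydrogen on the phenyl ring, para to a large group, gives a 1.9-fold higher number from compound 2 to compound 4 (0.27 log units; within the scatter) and so does not separate the two compounds: repeated measurements of one compound could differ as much, and this pair shows no real shift in either direction. Nothing shown here explains why the two numbers fall so close together.

From the compounds shown here alone, what a larger or different group would do at this same position remains open: chloro, a nitrile or an amine in place of the fluoro might give a step that stands clear of the scatter, or might not. It is also unknown whether the same swap would again leave the clearance unresolved at another carbon of this phenyl ring, or on the aromatic rings that compound 1 and compound 3 carry in its place.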